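Swapping an Aryl Ring for Furan in a Thiosemicarbazone

The source may hold more compounds than are shown below. What is called first, only, known or untested is meant among the compounds shown, and "the series" means these compounds.

Compound 1 `COc1ccc(/C=N/NC(=S)NC(C)(C)[C@H]2CC=C(C)CC2)cc1` and compound 2 `CC1=CC[C@H](C(C)(C)NC(=S)N/N=C/c2ccccc2[N+](=O)[O-])CC1` share a core that differs only in the aromatic ring hanging from the carbon with a double bond to nitrogen. In a functional assay on NCI-H460 cells (Homo sapiens) for inhibition, read by sulforhodamine B assay, with a stated time of 48 h (on this read-out lower numbers stand for stronger inhibition of growth and higher numbers for weaker inhibition of growth), compound 1 gives 47800 nM, and in this assay compound 2 gives 32700 nM. Compound 1 has the higher of these two numbers, but the gap to compound 2 lies within the scatter, so nothing separates them.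

Compound 3 `CC1=CC[C@H](C(C)(C)NC(=S)N/N=C/c2ccco2)CC1` is the next member: it carries furan-2-yl in place of 4-methoxyphenyl on a carbon with a double bond to nitrogen. For the measured compounds named here, with only two measured compounds, there is no measured step that shows what such a ring change does here. The step from compound 1 to compound 3 is expected to be a 1.1-fold lower number from compound 1 to compound 3 (0.03 log units; within the scatter), that is, no change beyond the scatter. Compound 3 is therefore expected to come out near 45000 nM in this assay, somewhere between 15000 nM and 130000 nM.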

Compound 3, concentration for total growth inhibition: 10800 nM
Compound 3: the middle estimate sits 4.2-fold (0.62 log units) above what was measured; measured number below the stated range.
By their numbers in this assay, from the lowest: compound 3; then compounds 2 and 1 (each within the scatter of the next).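

In this assay, furan-2-yl in place of 4-methoxyphenyl on a carbon with a double bond to nitrogen gives a 4.4-fold lower number from compound 1 to compound 3 (0.65 log units; beyond the scatter), so the ring at this position can move the number beyond the scatter. For the compounds shown here, compound 1 and compound 2 lie within the scatter of each other, so they gave no sign of this; the step is modest, but it is the first real change seen at this position. Nothing available here explains what about the furan-2-yl ring produces this step.

Going by these compounds, it remains open whether the step belongs to furan-2-yl alone or would also appear with another five-membered ring, such as thiophene, which has sulfur in place of the ring oxygen. Also open, on these data alone, is how a furan-2-yl ring carrying a methyl group or a carboxylic acid would behave at this position.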